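This account rests on a few compounds, and the source may have more. Where it says the series, first, only, none or still open, it means among the compounds named here.

Measured so far: compound 1 `CCOC(=O)/C(C#N)=C(/Nc1ccc([N+](=O)[O-])cc1)N[C@H](C)c1ccccc1`, compound 2 `CCOC(=O)/C(C#N)=C(/Nc1ccc(C(F)(F)F)cc1)N[C@H](C)c1ccccc1`, compound 3 `CCOC(=O)/C(C#N)=C(/Nc1ccc(Br)cc1)N[C@@H](C)c1ccccc1`.

In a functional assay on A-431 cells (Homo sapiens) for antiproliferative activity, read by MTT assay, with a stated time of 72 h, tested at 5 uM (a higher number here means more inhibition at the concentration tested (going by the name of the read-out), a lower number less inhibition), compound 1 gives 23.6%, compound 2 gives 43.1% and compound 3 gives 19.3%. Compound 3 carries the lowest of the three numbers, close to compound 1 and clearly behind compound 2. Compound 4 `CCOC(=O)/C(C#N)=C(/Nc1ccc(Br)cc1)N[C@H](C)c1ccccc1` has the same atoms and bonds as compound 3 and differs only in how one centre is drawn: the two compounds have the same atoms and bonds and differ only in configuration as drawn: 1 of 2 stereo elements differ; a stereocentre at a saturated chain carbon is drawn S in compound 3 and R in compound 4. Among the compounds with values here, no measured pair shows a change of this kind. The only step shown, a number 19.5 percentage points higher from compound 1 to compound 2 (beyond the scatter), concerns a group on the aromatic ring and so does not bear on it. With nothing to point in either direction, no step beyond the scatter is expected, so compound 4 is estimated at 21%, in a range from 8% to 36%, which means an expected step of a number 1.7 percentage points higher from compound 3 to compound 4 (within the scatter).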

Compound 4, a percentage reported as inhibition, at one concentration (the size of the read-out at that concentration, not a potency): 16.1%
Estimate against measurement, compound 4: 4.9 percentage points above; the measured number falls inside the stated range.
By their numbers in this assay, from the lowest: compounds 4, 3 and 1 (each within the scatter of the next); then compound 2.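

At this stereocentre, the drawn configuration makes no readable difference in this assay, with a number 3.2 percentage points lower from compound 3 to compound 4 (within the scatter) as the step, and the comparison is a clean one: the fact that compounds 3 and 4 differ only in the configuration as drawn. With the configuration of compound 4 now matching that of the others, bromo and nitro cannot be told apart, with a number 7.5 percentage points lower from compound 1 to compound 4 (within the scatter) as the step. Trifluoromethyl stands clear of bromo, with a number 27 percentage points lower from compound 2 to compound 4 (beyond the scatter) as the step.

As far as these compounds go, whether configuration matters as little with trifluoromethyl on the ring remains open. So does how a methoxy group or an amine on that aromatic carbon would compare.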